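The source may report more compounds than this note shows. Statements on the series, on what has been measured and on what is new or still open speak of the compounds shown alone.

Within the data shown here, in a functional assay on BGC-823 cells (Homo sapiens) for cytotoxicity, read by MTT assay (a higher number here means a weaker inhibitor, a lower number a stronger inhibitor), compound 2 `COc1cccc(/C=C/C(=O)c2sc(Nc3ccc(Cl)c(Cl)c3)nc2C)c1` gives 8350 nM, the only actual number among the three values shown. Compound 1 `Cc1ccc(Nc2nc(C)c(C(=O)/C=C/c3ccc(Cl)cc3)s2)cc1` gives > 25000 nM in this assay, which is a limit of the assay rather than a number. Compound 3 `Cc1cccc(Nc2nc(C)c(C(=O)/C=C/c3ccc(Cl)cc3)s2)c1` gives > 25000 nM, also a limit. Among the measured compounds shown here, the one step between measured compounds that differ in a single place, a step that the two limits leave unreadable from compound 1 to compound 3, cannot be read because the limit of > 25000 nM in this assay, at which 2 of the 3 values shown sit, covers both of its ends. Compound 4 `COc1ccc(/C=C/C(=O)c2sc(Nc3ccc(Cl)c(Cl)c3)nc2C)cc1` differs from compound 2 by 4-methoxyphenyl in place of 3-methoxyphenyl on a double-bonded chain carbon bound to a double-bonded chain carbon. For the measured compounds named here, no measured step swaps 3-methoxyphenyl for 4-methoxyphenyl, so nothing here sets a direction, and a change within the usual scatter is expected. The estimated step is a 1.0-fold lower number from compound 2 to compound 4 (0.02 log units; within the scatter). Compound 4 is therefore expected to give about 8000 nM, within 3000 nM to 25000 nM.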

Compound 4, half-maximal inhibitory concentration: > 25000 nM
Compound 4: a limit, no number; the forecaster's own chance of this, stated with the estimate: 20%; middle value at least 3.1-fold (0.49 log units) away from the limit.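

With the same atoms joined differently, 4-methoxyphenyl in place of 3-methoxyphenyl on a double-bonded chain carbon bound to a double-bonded chain carbon is not a silent change in this assay: the result is an at least 2.9-fold higher number from compound 2 to compound 4 (0.47 log units; beyond the scatter). Among these compounds, this is the first readable step here, and it shows that where the methoxy group sits on this ring matters in this pair. Compound 4 stands at a limit of the assay, so only the lower end of the step can be read: the limit of > 25000 nM in this assay, at which 3 of the 4 values shown sit.

Still open, on these data alone, is whether a hydroxyl or an amine in place of the methoxy group would keep the activity of compound 2. This single pair also leaves open whether the same change would matter with other groups on the shared core.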